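A few compounds are considered here, and "the series" means these few. Any claim that something is new, unique, unknown or untested is made for them only; others in the source may bear on it.

Of the compounds shown here, two with a shared core have been measured in a functional assay on isolated protein for inhibition of Glucose-dependent insulinotropic receptor (Rattus norvegicus), read by HTRF and cAMP accumulation; a higher number here means a larger maximal response, a lower number a smaller maximal response. Going by the values given here, compound 2 `Cc1nc(S(C)(=O)=O)ccc1Oc1ncnc(OC2CCN(C(=O)OC3(C(F)(F)F)CCC3)CC2)c1F` gives 82% in this assay, and compound 1 `Cc1nc(S(C)(=O)=O)ccc1Oc1ncnc(OC2CCN(C(=O)OC3CCC3)CC2)c1F` gives 81%; the two numbers lie together, as the only measured step, a number 1 percentage points higher from compound 1 to compound 2 (within the scatter), is within the usual scatter. Compound 3 `Cc1nc(S(C)(=O)=O)ccc1Oc1ncnc(OC2CCN(C(=O)OC3(C(F)(F)F)COC3)CC2)c1F` is the next compound. It differs from compound 2 in one place: 3-(trifluoromethyl)oxetan-3-yl in place of 1-(trifluoromethyl)cyclobutyl on an oxygen next to a carbonyl group. Among the compounds with values here, no measured step exchanges a four-membered carbon ring for one with a ring oxygen at this position, so the only guide is that the one step seen in this assay, trifluoromethyl in place of hydrogen on a saturated ring carbon, stayed within the scatter. Compound 3 is therefore expected to give about 80% in this assay, with a range from 68% to 92%. The expected step is a number 2 percentage points lower from compound 2 to compound 3 (within the scatter), which means no change beyond the scatter.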

Compound 3, largest response reached (reported as efficacy), in percent of the reference or control that the assay uses: 84%
Compound 3: middle estimate off by 4 percentage points, on the low side; the range from low to high includes it.
By their numbers in this assay, from the lowest: compounds 1, 2 and 3 (each within the scatter of the next).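

Exchanging 1-(trifluoromethyl)cyclobutyl for 3-(trifluoromethyl)oxetan-3-yl on an oxygen next to a carbonyl group gives a number 2 percentage points higher from compound 2 to compound 3 (within the scatter) in this assay, so at this position a four-membered ring with a hetero atom and a hydrogen-bond acceptor can replace the all-carbon ring without a change beyond the scatter. Measured against the plain cyclobutyl group, the ring oxygen and the trifluoromethyl group together give a number 3 percentage points higher from compound 1 to compound 3 (within the scatter), so even the two changes combined leave the maximal response within the scatter. Nothing available here explains why the response holds steady across these groups.

On these data alone, all three groups on this oxygen are four-membered rings, so whether an open chain such as tert-butyl or a group carrying an amine would hold the response remains open. As far as these compounds go, these numbers report only the largest response, so the concentration needed to reach it also remains unknown.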